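The source may hold more compounds than are shown below. What is called first, only, known or untested is meant among the compounds shown, and "the series" means these compounds.

Two compounds of the shared core carry a half-maximal cytotoxic concentration in an ADME assay on Huh-7 cells (Homo sapiens) for cytotoxicity, read by MTT assay, with a stated time of 4 h, at 37 degrees C; a lower number here means that less compound is tolerated, a higher number that more compound is tolerated. Compound 1 `Cn1c(=O)c(-c2c(F)cccc2F)cc2c(N)nc(Nc3ccccc3)nc21` gives 10400 nM in this assay. Compound 2 `COCCn1c(=O)c(-c2c(Cl)cccc2Cl)cc2c(N)nc(Nc3ccccc3)nc21` gives 241000 nM in this assay, which is the highest of the two numbers; the nearest is compound 1, whose number is lower by a gap beyond the scatter. Among the measured compounds shown here, compound 1 and compound 2 differ in more than one place, so no single step between them is available, and their two values show only that compound 2 is tolerated to a higher concentration.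

Compound 3 `CCCn1c(=O)c(-c2c(Cl)cccc2Cl)cc2c(N)nc(Nc3ccccc3)nc21` has not yet been measured in this assay. It differs from compound 2 in one place: methyl in place of methoxy on a saturated chain carbon, two bonds along the chain from an aromatic nitrogen.

For the measured compounds named here, with no measured pair isolating this change, the direction of the step is open. The expectation for compound 3 is a step of a 1.6-fold lower number from compound 2 to compound 3 (0.21 log units; within the scatter) that stays within or close to the usual scatter, with a slight lean toward a lower number. On that basis compound 3 is estimated at 150000 nM in this assay, with a range of 50000 nM to 400000 nM.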

Compound 3, half-maximal cytotoxic concentration: 181000 nM
Beside the measured number, compound 3's estimate is 1.2-fold (0.08 log units) below it; the range from low to high includes it.
By their numbers in this assay, from the lowest: compound 1; then compounds 3 and 2 (each within the scatter of the next).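

In this assay, among the compounds shown here, the exchange of methoxy for methyl on a saturated chain carbon, two bonds along the chain from an aromatic nitrogen, gives a 1.3-fold lower number from compound 2 to compound 3 (0.12 log units; within the scatter), the first step that isolates a single place. For this pair, 2-methoxyethyl and propyl are not told apart by this read-out, and the hydrogen-bond acceptor counted in methoxy can leave without a step beyond the scatter. Nothing measured on these compounds bears on why the two groups read alike.

Compound 1 differs from compound 2 and compound 3 in more than one place, so the steps from it cannot be read, and neither the chain on the aromatic nitrogen nor any other single place can be tied to its number. As far as these compounds go, whether the same holds at this position for an amine or a carboxylic acid at the end of the chain, or for a longer chain, stays open, since a single pair says nothing about groups beyond methoxy and methyl.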